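The source may hold more compounds than are shown below. What is called first, only, known or untested is meant among the compounds shown, and "the series" means these compounds.

Of the compounds shown here, three with a shared core have been measured in a functional assay on A-375 cells (Homo sapiens) for cytotoxicity, read by MTT assay, with a stated time of 72 h (a higher number here means a weaker inhibitor, a lower number a stronger inhibitor), so far. Among the measured compounds shown here, compound 1 (`O=C1c2c[n+]([O-])c3ccccc3c2C(=O)c2c1c1ccccc1n2Cc1cn([C@@H]2C[C@H](O)[C@@H](CO)O2)nn1`) gives 20 nM and compound 2 (`CC1(C)OCC(Cn2cc(Cn3c4c(c5ccccc53)C(=O)c3c[n+]([O-])c5ccccc5c3C4=O)nn2)O1`) gives 330 nM there, and the one measured step is large: a 17-fold higher number from compound 1 to compound 2 (1.22 log units; beyond the scatter) on exchanging the group on the aromatic nitrogen. Compound 3 (`CN1CCN(CCCCn2c3c(c4ccccc42)C(=O)c2c[n+]([O-])c4ccccc4c2C3=O)CC1`) gives 30 nM, which lies within the scatter of compound 1 and well under the number of compound 2.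

Compound 4 (`O=C1c2c[n+]([O-])c3ccccc3c2C(=O)c2c1c1ccccc1n2CCN1CCCCC1`) departs from compound 3 in its side chain: piperidin-1-yl in place of 2-(4-methylpiperazin-1-yl)ethyl on a saturated chain carbon, two bonds along the chain from an aromatic nitrogen. In words, this is piperidin-1-yl in place of 2-(4-methylpiperazin-1-yl)ethyl on a saturated chain carbon, two bonds along the chain from an aromatic nitrogen. For the measured compounds named here, no measured step covers this exchange. The step from compound 1 to compound 2 involves other groups, so it sets no size here and only warns that such changes can matter. Compound 3 itself, at 30 nM, is the natural anchor, so no step beyond the scatter is the expected outcome, with no firm direction. The estimate therefore means a 1.3-fold higher number from compound 3 to compound 4 (0.12 log units; within the scatter) as an expected step. Compound 4 is estimated in this assay at 40 nM (expected range 12 nM to 130 nM).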

Compound 4, half-maximal inhibitory concentration: 180 nM
Estimate against measurement, compound 4: 4.5-fold (0.65 log units) below; measured number above the stated range.
By their numbers in this assay, from the lowest: compounds 1 and 3 (each within the scatter of the next); then compounds 4 and 2 (each within the scatter of the next).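

In this assay the side chain on the aromatic nitrogen proves sensitive even when both chains end in a six-membered non-aromatic ring: the exchange of 4-(4-methylpiperazin-1-yl)butyl for 2-(piperidin-1-yl)ethyl gives a 6.0-fold higher number from compound 3 to compound 4 (0.78 log units; beyond the scatter). Among the compounds shown here, the only earlier step, a 17-fold higher number from compound 1 to compound 2 (1.22 log units; beyond the scatter), involved quite different groups, so this is the first sign that a change within the saturated amine side chains can also move the number beyond the scatter, although the two steps concern different exchanges and their sizes say nothing about each other. The exchange alters the chain and the ring together, from butyl to ethyl and from a ring with 2 hetero atoms to one with 1, and nothing available bears on why the number moves.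

On these data alone, compounds 3 and 4 cannot separate these two changes, so it remains open whether a 4-(piperidin-1-yl)butyl chain or a 2-(4-methylpiperazin-1-yl)ethyl chain would stand nearer compound 3 or compound 4. Also open, as far as these compounds go, is where a morpholine ring or a dimethylamino group at the end of such a chain would fall.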